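The source may hold more compounds than are shown below. What is called first, only, known or untested is meant among the compounds shown, and "the series" means these compounds.

In a functional assay on HOS cells (Homo sapiens) for antiproliferative activity, with a stated time of 72 h (a higher number here means a weaker inhibitor, a lower number a stronger inhibitor), compound 1 (`OC[C@H]1O[C@@H](n2cnc3c(NCc4cccc(Br)c4)ncnc32)[C@H](O)[C@@H]1O`) gives only a limit, > 166000 nM, and no number. Compound 2 (`OC[C@H]1O[C@@H](n2cnc3c(NCc4ccc(Cl)c(Cl)c4)ncnc32)[C@H](O)[C@@H]1O`) also gives only a limit, > 166000 nM. Compound 3 (`OC[C@H]1O[C@@H](n2cnc3c(NCc4ccc(F)cc4Cl)ncnc32)[C@H](O)[C@@H]1O`) likewise gives only a limit, > 166000 nM. All three therefore stand together at the limit of > 166000 nM in this assay, at which 3 of the 3 values shown sit. Compound 4 (`OC[C@H]1O[C@@H](n2cnc3c(NCc4ccc(F)c(Cl)c4)ncnc32)[C@H](O)[C@@H]1O`) differs from compound 3 in one change: 3-chloro-4-fluorophenyl in place of 2-chloro-4-fluorophenyl on a saturated chain carbon bound to a nitrogen on an aromatic ring. Among the measured compounds shown here, the steps that bear on it are a step that the two limits leave unreadable from compound 1 to compound 3, a step that the two limits leave unreadable from compound 2 to compound 3 and a step that the two limits leave unreadable from compound 1 to compound 2, and none has a measurable size. Thus, no change beyond the scatter is expected, and the expected step is a step that the limit leaves unreadable from compound 3 to compound 4. Compound 4 is estimated at 170000 nM, with an expected range from 80000 nM to 300000 nM.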

Compound 4, half-maximal inhibitory concentration: > 166000 nM
Compound 4: no number, only a limit; the forecaster's own chance of this, stated with the estimate: 85%; the middle value lies beyond the limit too.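

Compound 4, like compound 1, compound 2 and compound 3, gives only a limit, so no step among these compounds can be read: the limit of > 166000 nM in this assay, at which 4 of the 4 values shown sit.

What the compounds shown leave open is how any of these benzyl changes would act on potency in this assay.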